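Adding a Sulfonyl Group to the Ring Nitrogen of Compound 3

The compounds below may be only part of what the source reports. "The series", "measured", "known", "first", "only" and "open" are said of these compounds alone.

In a functional assay on GOTO cells (Homo sapiens) for cytotoxicity, read by MTT assay, with a stated time of 3 days (a lower number here means a stronger inhibitor, a higher number a weaker inhibitor), compound 1 (`N#Cc1c(Cl)nc(SCc2nc3ccccc3[nH]2)nc1-c1ccccc1`) gives 8.62 nM, compound 2 (`CCNc1nc(SCc2nc3ccccc3[nH]2)nc(-c2ccccc2)c1C#N`) gives 3.96 nM and compound 3 (`N#Cc1c(-c2ccccc2)nc(SCc2nc3ccccc3[nH]2)nc1N1CCNCC1`) gives 3.7 nM. Compound 3 and compound 2 stand level within the scatter, and both lie under compound 1. Ethylamino in place of chloro gives a 2.2-fold lower number from compound 1 to compound 2 (0.34 log units; beyond the scatter), and piperazin-1-yl in place of chloro gives a 2.3-fold lower number from compound 1 to compound 3 (0.37 log units; beyond the scatter). Piperazin-1-yl in place of ethylamino gives a 1.1-fold lower number from compound 2 to compound 3 (0.03 log units; within the scatter). Compound 4 (`N#Cc1c(-c2ccccc2)nc(SCc2nc3ccccc3[nH]2)nc1N1CCN(S(=O)(=O)c2ccccc2[N+](=O)[O-])CC1`) carries (2-nitrophenyl)sulfonyl in place of hydrogen on an amine nitrogen in a ring. Within the data shown here, no measured step touches that nitrogen, so these steps bear on it only indirectly. All three exchange a group on an aromatic carbon, and none is more than modest, which gives a weak reason to expect a small shift. With so large a group entering, a modest move to a higher number is expected, though the direction is uncertain. The expected step is a 1.6-fold higher number from compound 3 to compound 4 (0.21 log units; within the scatter). Compound 4 is estimated at 6 nM, with an expected range of 1.8 nM to 20 nM.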

Compound 4, half-maximal inhibitory concentration: 3 nM
Beside the measured number, compound 4's estimate is 2.0-fold (0.30 log units) above it; low and high end bracket the measured number.
By their numbers in this assay, from the lowest: compounds 4, 3 and 2 (each within the scatter of the next); then compound 1.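

In this assay the (2-nitrophenyl)sulfonyl in place of hydrogen on an amine nitrogen in a ring gives a 1.2-fold lower number from compound 3 to compound 4 (0.09 log units; within the scatter) and so leaves the two compounds level, even though 12 heavy atoms enter at this nitrogen. The earlier steps shown here all exchanged groups on an aromatic carbon, whereas this one shows that, for this single group, the hydrogen on the ring nitrogen is not needed to hold the number at this level. Nothing measured here explains why the number holds with so large a group in place.

The compounds shown leave open whether the sulfonyl link, the nitro group or the phenyl ring matters at this nitrogen, which an unsubstituted phenylsulfonyl, an acetyl or a benzyl group would help to separate. They also leave open how a small group such as methyl would behave there.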